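The source may report more compounds than this note shows. Statements on the series, on what has been measured and on what is new or still open speak of the compounds shown alone.

Measured so far:
compound 1, `C[C@@H](O[C@H]1CN2C(=O)C=C(c3ccc(CO)cc3)CC2[C@@H]1c1ccc(F)cc1)c1cc(C(F)(F)F)cc(C(F)(F)F)c1`: 0.39 nM
compound 2, `C[C@@H](O[C@H]1CN2C(=O)C=C(c3cc[n+]([O-])cc3)CC2[C@@H]1c1ccc(F)cc1)c1cc(C(F)(F)F)cc(C(F)(F)F)c1`: 0.1 nM
compound 3, `C[C@@H](O[C@H]1CN2C(=O)C=C(c3cnn(C)c3)CC2[C@@H]1c1ccc(F)cc1)c1cc(C(F)(F)F)cc(C(F)(F)F)c1`: 0.13 nM

In an assay on CHO cells for displacement of a labelled ligand from Substance-P receptor (Homo sapiens) (on this read-out lower numbers stand for stronger inhibition and higher numbers for weaker inhibition), compound 1 gives 0.39 nM, the highest of the three numbers. The nearest of the others is a 3.0-fold lower number from compound 1 to compound 3 (0.48 log units; beyond the scatter), the furthest is a 3.9-fold lower number from compound 1 to compound 2 (0.59 log units; beyond the scatter). Between the two heteroaromatic analogues the step is a 1.3-fold higher number from compound 2 to compound 3 (0.11 log units; within the scatter).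

Compound 4, `CCc1noc(C2=CC(=O)N3C[C@H](O[C@H](C)c4cc(C(F)(F)F)cc(C(F)(F)F)c4)[C@@H](c4ccc(F)cc4)C3C2)n1`, has not yet been measured in this assay. The change from compound 1 is 3-ethyl-1,2,4-oxadiazol-5-yl in place of 4-(hydroxymethyl)phenyl on a double-bonded ring carbon. Both measured steps from compound 1 also put a smaller aromatic ring with hetero atoms in place of the 4-(hydroxymethyl)phenyl on the same double-bonded ring carbon, and each gave a modest lower number beyond the scatter, with compound 2 and compound 3 within the scatter of each other. A third heteroaromatic ring at that position is therefore expected to give a modest lower number as well, a 2.6-fold lower number from compound 1 to compound 4 (0.41 log units; beyond the scatter), with no basis in the data for separating it from compound 2 or compound 3. Compound 4 is estimated at 0.15 nM, with a range of 0.06 nM to 0.4 nM.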

Compound 4, half-maximal inhibitory concentration: 0.4 nM
The estimate for compound 4 lay 2.7-fold (0.43 log units) below the measured number, and the stated range covers the measured number.
By their numbers in this assay, from the lowest: compounds 2 and 3 (each within the scatter of the next); then compounds 1 and 4 (each within the scatter of the next).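

The step from 4-(hydroxymethyl)phenyl to a smaller heteroaromatic ring on the double-bonded ring carbon does not lower the number as a general rule, since 3-ethyl-1,2,4-oxadiazol-5-yl leaves it within the scatter in this assay (a 1.0-fold higher number from compound 1 to compound 4 (0.01 log units; within the scatter)). The position also separates heteroaromatic rings from one another, which compounds 1 to 3 did not show: the 3-ethyl-1,2,4-oxadiazol-5-yl group stands apart from 1-methyl-1H-pyrazol-4-yl (a 3.1-fold higher number from compound 3 to compound 4 (0.49 log units; beyond the scatter)) and from the group of compound 2 (a 4.0-fold higher number from compound 2 to compound 4 (0.60 log units; beyond the scatter)). No measurement is at hand that accounts for these differences.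

Open, going by these compounds, is whether the ethyl chain or the ring itself carries the step, which a 3-methyl-1,2,4-oxadiazol-5-yl group would help to separate. Also open, on these data alone, is how an amine or a carboxylic acid on the ring would read at this position.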